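Swapping a methyl for a carbamoyl on the shared core

The compounds below may be only part of what the source reports. "The series", "measured", "known", "first", "only" and "open" are said of these compounds alone.

Of the compounds shown here, three built on one core have been measured. In a functional assay on the whole organism with Mus musculus as the target (on this read-out lower numbers stand for smaller maximal responses and higher numbers for larger maximal responses), compound 1 `Nc1nc(O)c2c(n1)n(C1OC(CO)[C@@H](O)[C@H]1O)c(=O)n2C/C=C/c1ccccc1` gives 5%. Compound 2 `CCOC(=O)Cn1c(=O)n(C2OC(CO)[C@@H](O)[C@H]2O)c2nc(N)nc(O)c21` gives 58% in this assay, and compound 3 `CCn1c(=O)n(C2OC(CO)[C@@H](O)[C@H]2O)c2nc(N)nc(O)c21` gives 82% there. Compound 3 therefore stands highest of the three, with compound 2 nearest and compound 1 furthest. The single-site steps read a number 53 percentage points higher from compound 1 to compound 2 (beyond the scatter), a number 77 percentage points higher from compound 1 to compound 3 (beyond the scatter) and a number 24 percentage points higher from compound 2 to compound 3 (beyond the scatter).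

Compound 4 `NC(=O)Cn1c(=O)n(C2OC(CO)[C@@H](O)[C@H]2O)c2nc(N)nc(O)c21` differs from compound 3 by carbamoyl in place of methyl on a saturated chain carbon bound to an aromatic nitrogen. Going by the values given here, the step that bears on this exchange is the one between compound 2 and compound 3, since compound 2 also carries a group with a carbonyl on that chain carbon; it was modest, a number 24 percentage points higher from compound 2 to compound 3 (beyond the scatter). The two large steps from compound 1 concern a 2-phenylethenyl and do not speak to a carbamoyl. Running the modest step in reverse, the author expects a modest lowering for compound 4, a number 22 percentage points lower from compound 3 to compound 4 (beyond the scatter), beyond the scatter but far short of the drop seen with compound 1. His estimate for compound 4 in this assay is 60%, within a range from 35% to 85%.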

Compound 4, largest response reached (reported as maximal response), in percent of the reference or control that the assay uses: 72%
Beside the measured number, compound 4's estimate is 12 percentage points below it, within the range that was stated.
By their numbers in this assay, from the lowest: compound 1; then compound 2; then compounds 4 and 3 (each within the scatter of the next).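

In this assay, going by these compounds alone, putting carbamoyl in place of methyl on a saturated chain carbon bound to an aromatic nitrogen gives a number 10 percentage points lower from compound 3 to compound 4 (within the scatter), the first exchange at this place that stays inside the scatter, whereas the steps to compound 3 from compound 1 and compound 2 both lay beyond it. A carbonyl on this chain therefore does not by itself go with the lower number of compound 2, since amino in place of ethoxy on the carbonyl carbon gives a number 14 percentage points higher from compound 2 to compound 4 (beyond the scatter) and shows that the group on that carbon counts. The large step of a number 67 percentage points higher from compound 1 to compound 4 (beyond the scatter) leaves compound 1, with its 2-phenylethenyl, standing apart from the other three.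

Nothing in the data shown explains why the amide and the methyl fall within the scatter of each other in this whole-organism read-out. Open too, from the compounds shown here alone, is whether a carboxylic acid, an amine or a longer chain at this place would stay with compound 3 and compound 4 or fall towards compound 2, and whether a methyl on the amide nitrogen would keep the number of compound 4.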